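The compounds below may be only part of what the source reports. "The series", "measured", "known", "first", "only" and "open" are said of these compounds alone.

Measured so far in a functional assay on RS4-11 cells (Homo sapiens) for inhibition, read by CCK-8 assay, with a stated time of 48 h, tested at 20 uM; a lower number here means less inhibition of growth, a higher number more inhibition of growth at the concentration tested
- compound 1 `Cc1ccc(S(=O)(=O)Oc2cccc(/C=C(\C#N)C(=O)Nc3nnc(C)s3)c2)cc1` gives 28% 
- compound 2 `COc1ccc(-c2nnc(NC(=O)/C(C#N)=C/c3cccc(OS(=O)(=O)c4ccc(C)cc4)c3)s2)cc1` gives 79% 
- compound 3 `COc1ccccc1-c1nnc(NC(=O)/C(C#N)=C/c2cccc(OS(=O)(=O)c3ccc(C)cc3)c2)s1` gives 41% 

Compound 3 holds the middle place of the three, with a number 13 percentage points higher from compound 1 to compound 3 (beyond the scatter) on one side and a number 38 percentage points lower from compound 2 to compound 3 (beyond the scatter) on the other. The next change leads to compound 4 `Cc1ccc(S(=O)(=O)Oc2cccc(/C=C(\C#N)C(=O)Nc3nnc(-c4cccs4)s3)c2)cc1`, with thiophen-2-yl in place of 2-methoxyphenyl on an aromatic carbon of the shared core. All three measured steps concern this same carbon. Replacing methyl with an aromatic group gave a number 51 percentage points higher from compound 1 to compound 2 (beyond the scatter) and also a number 13 percentage points higher from compound 1 to compound 3 (beyond the scatter), so both aromatic compounds stand above compound 1, and neither goes against that. Between the two methoxyphenyl groups alone there is a number 38 percentage points lower from compound 2 to compound 3 (beyond the scatter) in this series. Among the measured compounds shown here, no measured compound carries thiophen-2-yl, so none of these steps measures the change directly, and their spread argues for a wide range. Compound 3 at 41% is the lower of the two aromatic compounds, so a moderate rise in this assay is expected rather than a fall. The expected size is a number 17 percentage points higher from compound 3 to compound 4 (beyond the scatter) by this estimate. Compound 4 is expected at 58% within an estimated range of 35% to 80% in this read-out.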

Compound 4, percent growth inhibition at one concentration: 25%
Compound 4: middle estimate off by 33 percentage points, on the high side; the measured number lies below the stated range.
By their numbers in this assay, from the lowest: compounds 4 and 1 (each within the scatter of the next); then compound 3; then compound 2.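

In this assay, among the compounds shown here, an aromatic group on this carbon no longer brings a gain by itself: with thiophen-2-yl there is a number 3 percentage points lower from compound 1 to compound 4 (within the scatter), so compound 4 is the first aromatic compound here that does not stand above compound 1. The aromatic groups also separate clearly from one another, with a number 16 percentage points lower from compound 3 to compound 4 (beyond the scatter) and a number 54 percentage points lower from compound 2 to compound 4 (beyond the scatter), so among the compounds shown the high number goes with 4-methoxyphenyl alone, not with aromatic groups on this carbon in general. No measurement at hand bears on what lies behind these differences.

Open, on these data alone, is whether the methoxy group is needed at all for the high number of compound 2, a question that plain phenyl on the same carbon would address, while a phenyl ring carrying an amine or a carboxylic acid would show how far other substituents on that ring are tolerated. Also open, as far as these compounds go, is whether the order seen at this one concentration would hold across a full range of concentrations or in other cell lines.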